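Swapping an amino-linked pyrazole for a directly attached one

The source may hold more compounds than are shown below. What is called first, only, known or untested is meant among the compounds shown, and "the series" means these compounds.

- compound 1 `CN(C)C(=O)c1cc(-c2cnc(NCc3c(F)ccc4c3CCO4)c3cn[nH]c(=O)c23)n(C)n1`: 21 mL.min-1.g-1
- compound 2 `CNC(=O)c1ccc(-c2cnc(NCc3c(F)ccc4c3CCO4)c3cn[nH]c(=O)c23)c(C)n1`: 23 mL.min-1.g-1
- compound 3 `CN(c1ccn(C)n1)c1cnc(NCc2c(F)ccc3c2CCO3)c2cn[nH]c(=O)c12`: 62 mL.min-1.g-1

In an ADME assay on microsomes from liver (Homo sapiens) for metabolic stability, read by LC-MS, using NADPH, with stated times of 5 min and 30 min, tested at 1 uM (on this read-out lower numbers stand for slow clearance and higher numbers for fast clearance), compound 3 has the highest of the three numbers. Compound 4 `Cc1nn(C)cc1-c1cnc(NCc2c(F)ccc3c2CCO3)c2cn[nH]c(=O)c12` is still unmeasured. Its difference from compound 3 is 1,3-dimethyl-1H-pyrazol-4-yl in place of methyl(1-methyl-1H-pyrazol-3-yl)amino on an aromatic carbon: 1,3-dimethyl-1H-pyrazol-4-yl replaces methyl(1-methyl-1H-pyrazol-3-yl)amino on an aromatic carbon.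

Among the measured compounds shown here, two measured steps bear on this change: a 3.0-fold higher number from compound 1 to compound 3 (0.47 log units; beyond the scatter) and a 2.7-fold higher number from compound 2 to compound 3 (0.43 log units; beyond the scatter). Both put the methyl(1-methyl-1H-pyrazol-3-yl)amino group in place of other groups. Compound 4 lacks the carbamoyl groups of compound 1 and compound 2, so the parallel is imperfect.

A modest drop in this assay is therefore expected, namely a 2.1-fold lower number from compound 3 to compound 4 (0.32 log units; beyond the scatter). For compound 4, the estimated value is 30 mL.min-1.g-1, with an expected range of 15 mL.min-1.g-1 to 55 mL.min-1.g-1.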

Compound 4, intrinsic clearance in microsomes in the Homo sapiens assay: 27 mL.min-1.g-1
For compound 4 the middle estimate is 1.1-fold (0.05 log units) above the measured one; low and high end bracket the measured number.
By their numbers in the Homo sapiens assay, from the lowest: compounds 1, 2 and 4 (each within the scatter of the next); then compound 3.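

In the Homo sapiens assay, replacing the amino-linked pyrazole with 1,3-dimethyl-1H-pyrazol-4-yl on this aromatic carbon gives a 2.3-fold lower number from compound 3 to compound 4 (0.36 log units; beyond the scatter), so a directly attached pyrazole with no carbamoyl group can still match the carbamoyl compounds. In the Homo sapiens assay, both comparisons stay level: a 1.2-fold higher number from compound 2 to compound 4 (0.07 log units; within the scatter) and a 1.3-fold higher number from compound 1 to compound 4 (0.11 log units; within the scatter). In a physicochemical assay for lipophilicity, using the shake flask method, in phosphate buffer, measured as octanol-water partition, with a stated time of 30 min, at pH 7.4 (on this read-out lower numbers stand for lower lipophilicity and higher numbers for higher lipophilicity), compound 3 gives 2.4 and compound 4 gives 2.8. Lower lipophilicity cannot explain the lower clearance, since the number rose in the physicochemical assay: the measured distribution coefficient of compound 3, 2.4, and of compound 4, 2.8, a number 0.40 log units higher (beyond the scatter)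

On these data alone, the change alters the amine link and the pyrazole's attachment together, so their separate contributions remain open. As far as these compounds go, how a morpholine on this carbon would behave also remains open.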